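Isopropoxy to ethoxy on the shared core

The compounds below may be only part of what the source reports. "The series", "measured", "known", "first", "only" and "open" are said of these compounds alone.

Measured so far in an ADME assay on MDCK cells (Canis lupus familiaris) for cytotoxicity, with a stated time of 48 h; on this read-out lower numbers stand for higher toxicity in this test and higher numbers for lower toxicity in this test:

compound 1, `CC(C)OCCCNC(=O)c1csc(Nc2ccc(Cl)c(Cl)c2)n1`: 100000 nM
compound 2, `CCOCCCNC(=O)c1csc(Nc2ccc(Cl)c(Cl)c2)n1`: > 100000 nM, a limit of the assay
compound 3, `Cc1cc(Nc2nc(C(=O)NCCCOC(C)C)cs2)cc(C)c1Cl`: > 100000 nM, a limit of the assay

Compounds 1 and 2 share a core and differ by hydrogen in place of methyl on a saturated chain carbon bound to an oxygen on a saturated carbon and a saturated chain carbon. This change made the step of a number no lower from compound 1 to compound 2 (the limit leaves the size open). The value of compound 2 is a limit of the assay, and the size of the step is therefore not readable; what can be said is that two of the three values shown sit at the limit of > 100000 nM in this assay, at which 2 of the 3 values shown sit.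

Compound 3 carries a different core; the difference between the core of compound 1 and the core of compound 3 is not broken down here. Compound 4, `CCOCCCNC(=O)c1csc(Nc2cc(C)c(Cl)c(C)c2)n1`, is not yet measured in this assay and differs from compound 3 by hydrogen in place of methyl on a saturated chain carbon bound to an oxygen on a saturated carbon and a saturated chain carbon. The place of this change reads the same word for word as in the pair of compound 1 and compound 2, so it is the same change.

Compound 4 is expected to be at or near the limit of this assay, and the step from compound 3 to compound 4 is estimated as a number no higher from compound 3 to compound 4 (the limit leaves the size open). This expectation rests on the step of a number no lower from compound 1 to compound 2 (the limit leaves the size open), which gave no lower number after the same change, and on (the limit of > 100000 nM in this assay, at which 2 of the 3 values shown sit), at which compound 3 stands. For compound 4 the estimate in this assay is 100000 nM, between 50000 nM and 200000 nM.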

Compound 4, half-maximal cytotoxic concentration: > 100000 nM
Compound 4: no number, only a limit; the forecaster's own chance of this, stated with the estimate: 75%; the middle value lies on the limit itself.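

In this assay compound 4 gives > 100000 nM, which is a limit of the assay. Compound 3 and compound 4 both stand at a limit, and no step can be read between them. The compounds shown leave open how far compound 2, compound 3 and compound 4 lie from that limit, and what isopropoxy to ethoxy does to the read-out on either core: the limit of > 100000 nM in this assay, at which 3 of the 4 values shown sit.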